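Carbonyl substituent change from compound 3 to compound 4

The source may hold more compounds than are shown below. What is called first, only, known or untested is meant among the compounds shown, and "the series" means these compounds.

Measured compounds:
compound 1 `COC(=O)C1=C(C)NC(=O)NC1c1cccs1` — 3%
compound 2 `CCN(CC)C(=O)C1=C(C)NC(=O)NC1c1ccoc1` — 37%
compound 3 `CCN(CC)C(=O)C1=C(C)NC(=O)NC1c1cccs1` — 31%

In an assay on membranes from HeLa cells for displacement of a labelled ligand from adenosine receptor A3 (Homo sapiens), read by scintillation counting, with a stated time of 180 min, tested at 1 uM (a higher number here means more inhibition at the concentration tested (going by the name of the read-out), a lower number less inhibition), compound 3 gives 31%, the second highest of the three numbers. Its nearest neighbour is compound 2 with 37%; the step of a number 6 percentage points lower from compound 2 to compound 3 (within the scatter) is within the scatter, so no order between these two can be read. Compound 1 gives 3%, and the step of a number 28 percentage points higher from compound 1 to compound 3 (beyond the scatter) lies beyond the scatter.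

Compound 4 `CC1=C(C(=O)OCC2CCC2)C(c2cccs2)NC(=O)N1` differs from compound 3 in one place: cyclobutylmethoxy in place of diethylamino on a carbonyl carbon. Going by the values given here, the only measured step bearing on this carbonyl carbon is a number 28 percentage points higher from compound 1 to compound 3 (beyond the scatter), in which diethylamino in place of methoxy raised inhibition. Among the compounds with values here, compound 4 moves in the opposite direction, back to an oxygen-linked substituent, though cyclobutylmethoxy rather than methoxy; no measured pair compares two such substituents, so the size of the cyclobutylmethyl effect is unknown. A drop beyond the scatter is therefore expected, tempered by the uncertainty of the larger group. Compound 4 is estimated at 14% in this assay, with a range from 0% to 35%, meaning an expected step of a number 17 percentage points lower from compound 3 to compound 4 (beyond the scatter).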

Compound 4, a percentage reported as inhibition, at one concentration (the size of the read-out at that concentration, not a potency): 1%
The estimate for compound 4 lay 13 percentage points above the measured number; low and high end bracket the measured number.
By their numbers in this assay, from the lowest: compounds 4 and 1 (each within the scatter of the next); then compounds 3 and 2 (each within the scatter of the next).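

In this assay, cyclobutylmethoxy in place of diethylamino gives a step of a number 30 percentage points lower from compound 3 to compound 4 (beyond the scatter), so the earlier gain from diethylamino over methoxy now has a counterpart with a second, larger oxygen-linked group: with thiophen-2-yl held constant, compound 3 stands beyond the scatter from both compound 1 and compound 4. The added cyclobutyl gives a step of a number 2 percentage points lower from compound 1 to compound 4 (within the scatter), so methoxy and cyclobutylmethoxy cannot be told apart at this carbonyl carbon, and the larger oxygen-linked group recovers none of the inhibition seen with diethylamino. No measurement available here accounts for the difference between the diethylamino and oxygen-linked compounds.

Open, as far as these compounds go, is whether the nitrogen link itself or the two ethyl groups carry the higher reading, a question that a pyrrolidine amide, a monoethyl amide or a carboxylic acid at the same carbonyl carbon would help to separate. Also open, from the compounds shown here alone, is whether the same drop holds with furan-3-yl in place of thiophen-2-yl, as the furan-3-yl series here has only its diethylamino member, compound 2.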